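The compounds below may be only part of what the source reports. "The series", "measured", "known", "first", "only" and "open" are said of these compounds alone.

Series notes. Compound 1 `Cc1ccc(C(=O)c2ccc3c(ccn3Cc3ccc(C(=O)NO)cc3)c2)cc1` gives 11.9 nM in an assay on isolated protein for inhibition of protein deacetylase HDAC6 (Homo sapiens); a higher number here means a weaker inhibitor, a lower number a stronger inhibitor. For the measured compounds named here, compound 2 `COc1ccc(C(=O)c2ccc3c(ccn3Cc3ccc(C(=O)NO)cc3)c2)cc1OC` gives 15.5 nM in this assay and stands second highest of the three numbers so far: nearest is compound 1, a difference within the scatter, and furthest is compound 3 `COc1cc(C(=O)c2ccc3c(ccn3S(=O)(=O)c3ccc(/C=C/C(=O)NO)cc3)c2)cc(OC)c1OC`, which gives 972 nM in this assay. Compound 4 `COc1cccc(C(=O)c2ccc3c(ccn3Cc3ccc(C(=O)NO)cc3)c2)c1` is not yet measured. Its change from compound 2: hydrogen in place of methoxy on an aromatic carbon. Going by the values given here, only one measured step touches the aryl group on the carbonyl carbon, a 1.3-fold higher number from compound 1 to compound 2 (0.11 log units; within the scatter), and it stays within the scatter. Among the compounds with values here, compound 3 differs from compound 2 in more than one place, so its value shows only that a much higher number is reachable, not what removing a single methoxy does. The step is therefore expected to be small, a 1.1-fold lower number from compound 2 to compound 4 (0.04 log units; within the scatter), with no direction beyond the scatter. Compound 4 is expected at 14 nM, in a range of 7 nM to 28 nM.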

Compound 4, half-maximal inhibitory concentration: 16.4 nM
Beside the measured number, compound 4's estimate is 1.2-fold (0.07 log units) below it; measured number inside the range.
By their numbers in this assay, from the lowest: compounds 1, 2 and 4 (each within the scatter of the next); then compound 3.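

In this assay, hydrogen in place of the methoxy that stands para to a large group and ortho to a methoxy group gives a 1.1-fold higher number from compound 2 to compound 4 (0.02 log units; within the scatter), so this single position is now read on its own, and 3,4-dimethoxyphenyl and 3-methoxyphenyl are not separated. A second comparison on the carbonyl carbon, 3-methoxyphenyl in place of 4-methylphenyl, gives a 1.4-fold higher number from compound 1 to compound 4 (0.14 log units; within the scatter), so the three aryl groups of compound 1, compound 2 and compound 4 all fall within the scatter of one another. No measurement shown bears on why this change leaves the number so little moved.

From the compounds shown here alone, whether an amine or a carboxylic acid at this position would stay within the scatter remains open. Compound 3 differs from these compounds in more than one place. It is not compared with them here.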